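This account rests on a few compounds, and the source may have more. Where it says the series, first, only, none or still open, it means among the compounds named here.

Measured so far in a functional assay on MGC-803 cells (Homo sapiens) for antiproliferative activity, read by CCK-8 assay, with a stated time of 72 h; a higher number here means a weaker inhibitor, a lower number a stronger inhibitor:
- compound 1 `CN(CC(=O)N(Cc1ccc(C2CCCCC2)cc1)c1ccc(B(O)O)cc1)S(=O)(=O)c1c(F)c(F)c(F)c(F)c1F`: 4730 nM
- compound 2 `O=C([C@H]1CCCN1S(=O)(=O)c1c(F)c(F)c(F)c(F)c1F)N(Cc1ccc(C2CCCCC2)cc1)c1ccc(B(O)O)cc1`: 6070 nM

Compound 1 and compound 2 lie within the scatter of each other, so compound 1 does not stand apart on these numbers. Compound 3 `C[C@H](C(=O)N(Cc1ccc(C2CCCCC2)cc1)c1ccc(B(O)O)cc1)N(C)S(=O)(=O)c1c(F)c(F)c(F)c(F)c1F` keeps the core of compound 1, with one change methyl in place of hydrogen on a saturated chain carbon bound to a carbonyl carbon and a sulfonamide nitrogen. Among the measured compounds shown here, no measured step isolates this change, so no step beyond the scatter is expected in this assay, in either direction. The estimated change is a 1.1-fold higher number from compound 1 to compound 3 (0.02 log units; within the scatter). For compound 3 the expected value is 5000 nM, within an estimated range of 2200 nM to 11000 nM.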

Compound 3, half-maximal inhibitory concentration: 3130 nM
Beside the measured number, compound 3's estimate is 1.6-fold (0.20 log units) above it; low and high end bracket the measured number.
By their numbers in this assay, from the lowest: compounds 3, 1 and 2 (each within the scatter of the next).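

Methyl in place of hydrogen on a saturated chain carbon bound to a carbonyl carbon and a sulfonamide nitrogen gives, in this assay, a 1.5-fold lower number from compound 1 to compound 3 (0.18 log units; within the scatter) and so leaves the number unchanged within the usual scatter. This position thus accepts one added methyl with no step beyond the scatter in this assay. Nothing measured here speaks to the origin of this small step. Open, on these data alone, is whether an ethyl group, a longer chain, an amine or a carboxylic acid on this carbon would also stay within the scatter of compound 1.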